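The source may hold more compounds than are shown below. What is called first, only, known or untested is meant among the compounds shown, and "the series" means these compounds.

Compound 1, `CCOC(=O)C(CCCCCN)CSC(C)=O`, compound 2, `CCOC(=O)C(CCCCCN)C[Se]C(=O)CC`, and compound 3, `NCCCCCC(C[Se]C(=O)CCc1ccccc1)C(=O)O`, share a core that carries an amine-terminated chain and an ester or acid, and differ in the acyl group attached to the sulfur or selenium. In an assay on isolated protein for inhibition of carboxypeptidase B (Sus scrofa), read by spectrophotometry, with stated times of 10 min and 30 min (on this read-out higher numbers stand for weaker inhibition and lower numbers for stronger inhibition), compound 1 gives 19000 nM, compound 2 gives 910000 nM, and compound 3 gives 1400 nM, the lowest of the three numbers, with compound 1 nearer to it and compound 2 far above it. The single step among these three, a 48-fold higher number from compound 1 to compound 2 (1.68 log units; beyond the scatter), exchanges both the chalcogen and the acyl chain at once and so speaks only loosely to the question here.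

Compound 4, `NCCCCCC(C[Se]C(=O)CCCc1ccccc1)C(=O)O`, differs from compound 3 by benzyl in place of phenyl on a saturated chain carbon, two bonds along the chain from a carbonyl carbon, so the acyl chain on selenium grows by one carbon while the aromatic ring and the acid are kept. Among the measured compounds shown here, no measured pair isolates such a lengthening of the acyl chain on its own; the one step that touches the same place combines several changes and is therefore no direct guide. On that basis compound 4 is expected to give a number close to that of compound 3, with a 1.1-fold higher number from compound 3 to compound 4 (0.03 log units; within the scatter) lying within the scatter in either direction. The estimate for compound 4 in this assay is 1500 nM, in a range from 500 nM to 4500 nM.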

Compound 4, half-maximal inhibitory concentration: 1500 nM
The estimate for compound 4 equals the measured number at the digits printed; the measured number falls inside the stated range.
By their numbers in this assay, from the lowest: compounds 3 and 4 (each within the scatter of the next); then compound 1; then compound 2.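

In this assay, among the compounds shown here, a 1.1-fold higher number from compound 3 to compound 4 (0.03 log units; within the scatter) is the first step that can be read as a single change: benzyl in place of phenyl on a saturated chain carbon, two bonds along the chain from a carbonyl carbon, with the selenium, the acid and the amine-terminated chain all kept. For the compounds shown here, it shows that, in this selenium acid series, the acyl chain can be lengthened from phenyl to benzyl at this place without moving the number beyond the scatter, something the one earlier step could not show, as it changed the chalcogen and the acyl chain together. Nothing measured here offers an explanation for this result.

The compounds shown leave open whether a still longer chain at this place, or a hydroxyl group or an amine on the aromatic ring, would leave the number within the scatter of compound 3 and compound 4. They also leave open how much of the gap to compound 1 and compound 2 belongs to the acid, the ethyl ester, the chalcogen or the acyl group, and whether sulfur in place of selenium would change the number with the benzyl group in place.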